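Chlorines in Place of Fluorine and Methoxy on a Chalcone

This account rests on a few compounds, and the source may have more. Where it says the series, first, only, none or still open, it means among the compounds named here.

Of the compounds shown here, three built on a shared core have been tested in a functional assay on K562 cells (Homo sapiens) for antiproliferative activity, read by MTT assay, with a stated time of 24 h; on this read-out lower numbers stand for stronger inhibition and higher numbers for weaker inhibition. Compound 1 `COc1ccc(/C=C/C(=O)c2ccc(OC)c3c2OC(C)(C)C=C3)c(F)c1` carries a 2-fluoro-4-methoxyphenyl on its chain; in this assay compound 1 gives > 10000 nM, which is a limit of the assay and not a number. Compound 2 `COc1cc(OC)c(OC)cc1/C=C/C(=O)c1ccc(OC)c2c1OC(C)(C)C=C2` likewise reaches only > 10000 nM, a limit. Compound 3 `COc1ccc(C(=O)/C=C/c2cccc3ccccc23)c2c1C=CC(C)(C)O2` gives > 10000 nM, again a limit. Going by the values given here, no step between any two of these can therefore be sized; the whole picture is summed up by the limit of > 10000 nM in this assay, at which 3 of the 3 values shown sit, so compound 1 stands nowhere in particular among them but shares their common ceiling.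

Compound 4 `COc1ccc(C(=O)/C=C/c2ccc(Cl)c(Cl)c2)c2c1C=CC(C)(C)O2` has not yet been measured in this assay. It differs from compound 1 by 3,4-dichlorophenyl in place of 2-fluoro-4-methoxyphenyl on a double-bonded chain carbon bound to a double-bonded chain carbon. Among the compounds with values here, since every measured value sits at the same limit, there is no measured step to lean on, and the expected step that the limit leaves unreadable from compound 1 to compound 4 is taken to be small, with no clear direction and no confident departure from the scatter. Compound 4 is accordingly expected to give about 12000 nM in this assay, with a range from 3000 nM to 40000 nM, and it is considered likely that a limit rather than a number will again be reported.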

Compound 4, half-maximal inhibitory concentration: 9030 nM
Beside the measured number, compound 4's estimate is 1.3-fold (0.12 log units) above it; low and high end bracket the measured number.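

In this assay, going by these compounds alone, 3,4-dichlorophenyl in place of 2-fluoro-4-methoxyphenyl on a double-bonded chain carbon bound to a double-bonded chain carbon gives the first reading here that is a number rather than a limit, and the change comes with an at least 1.1-fold lower number from compound 1 to compound 4 (0.04 log units; that floor lies within the scatter). Within the data shown here, this position can therefore yield a measurable value on the shared core, which none of the earlier compounds showed, and compound 4 is now the one point from which a later step at this place could be sized. Yet the printed figure is only a floor that lies within the scatter, so the change cannot be called a true gain, and no step involving compound 2 or compound 3 can be read.

The compounds shown leave open how large the step from the fluorinated compound really is, since the other values mark only a ceiling: the limit of > 10000 nM in this assay, at which 3 of the 4 values shown sit. They also leave open whether a phenyl ring carrying a single chlorine, an amine or a carboxylic acid at this place would give a number clearly apart from that of compound 4.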